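Returning the indanylamine to a tryptamine piperidine series

A few compounds are considered here, and "the series" means these few. Any claim that something is new, unique, unknown or untested is made for them only; others in the source may bear on it.

Compound 2: `CN(Cc1cccs1)C1CCN(CCCc2c[nH]c3ccc(-n4cnnc4)cc23)CC1`, 140 nM
Compound 1: `O[C@H]1Cc2ccccc2C1NC1CCN(CCCc2c[nH]c3ccc(-n4cnnc4)cc23)CC1`, 300 nM

In an assay on CHO cells for displacement of a labelled ligand from 5-hydroxytryptamine receptor 1B (Homo sapiens) (a lower number here means a stronger inhibitor, a higher number a weaker inhibitor), compound 2 gives the lowest of the two numbers, with compound 1 the nearest at 300 nM. Compound 3, `O[C@@H]1Cc2ccccc2[C@H]1NC1CCN(CCCc2c[nH]c3ccc(-n4cnnc4)cc23)CC1`, differs from compound 2 in that ((2-hydroxy-2,3-dihydro-1H-inden-1-yl)amino in place of methyl((thiophen-2-yl)methyl)amino on a saturated ring carbon). Among the measured compounds shown here, the one measured step that bears on this is a 2.1-fold lower number from compound 1 to compound 2 (0.33 log units; beyond the scatter), the same exchange in the opposite direction. Compound 3 is therefore expected to give a number higher than compound 2 by about a 2.1-fold higher number from compound 2 to compound 3 (0.33 log units; beyond the scatter). Compound 3 is estimated at 300 nM, within the range 120 nM to 800 nM.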

Compound 3, half-maximal inhibitory concentration: 210 nM
Compound 3: the middle estimate sits 1.4-fold (0.15 log units) above what was measured, and the stated range covers the measured number.
By their numbers in this assay, from the lowest: compounds 2, 3 and 1 (each within the scatter of the next, the first and the last beyond it).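

In this assay, the step of a 1.5-fold higher number from compound 2 to compound 3 (0.18 log units; within the scatter) leaves (2-hydroxy-2,3-dihydro-1H-inden-1-yl)amino and methyl((thiophen-2-yl)methyl)amino on this saturated ring carbon not distinguishable, whereas the step involving compound 1 had separated them. The step of a 1.4-fold lower number from compound 1 to compound 3 (0.15 log units; within the scatter) also lies within the scatter, but it cannot be read as the effect of configuration alone: the fact that one of compounds 1 and 3 is drawn with a defined configuration and the other without, at the place where they differ

The compounds shown leave open how other fully defined stereoisomers of this group compare with compound 3. They also leave open what a dimethylamino group or a morpholine on the same carbon gives.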